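The compounds below may be only part of what the source reports. "The series", "measured", "known", "first", "only" and "open" are said of these compounds alone.

Compound 1 `CC1(C)[C@H]2CC[C@]1(C)N(Cc1cn(-c3ccc(C#N)cc3)nn1)C(=O)C2` gives 140 nM in a functional assay on A549 cells (Homo sapiens) for inhibition, read by MTT assay, with a stated time of 24 h (on this read-out lower numbers stand for stronger inhibition and higher numbers for weaker inhibition), which stands at the low end of the three numbers shown, though both other compounds lie within the scatter of it. Compound 2 `CC1(C)[C@H]2CC[C@]1(C)N(Cc1cn(-c3ccc(F)cc3)nn1)C(=O)C2` gives 230 nM, and compound 3 `CC1(C)[C@H]2CC[C@]1(C)N(Cc1cn(-c3ccccc3O)nn1)C(=O)C2` gives 230 nM; the steps were a 1.6-fold higher number from compound 1 to compound 2 (0.22 log units; within the scatter) and a 1.6-fold higher number from compound 1 to compound 3 (0.22 log units; within the scatter). Compound 4 `CC1(C)[C@H]2CC[C@]1(C)N(Cc1cn(-c3cccc(O)c3)nn1)C(=O)C2` differs from compound 1 in one place: 3-hydroxyphenyl in place of 4-cyanophenyl on an aromatic nitrogen. The step from compound 1 to compound 3, which also places a hydroxyphenyl on the same aromatic nitrogen, bears most directly on this change, and it stayed within the scatter, as did the step to compound 2. No shift beyond the scatter is therefore expected in this assay for compound 4. Compound 4 is estimated at 230 nM, between 110 nM and 480 nM, which would mean a 1.6-fold higher number from compound 1 to compound 4 (0.22 log units; within the scatter).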

Compound 4, half-maximal inhibitory concentration: 180 nM
Estimate against measurement, compound 4: 1.3-fold (0.11 log units) above, within the range that was stated.
By their numbers in this assay, from the lowest: compounds 1, 4, 2 and 3 (each within the scatter of the next).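

Placing 3-hydroxyphenyl in place of 2-hydroxyphenyl on the aromatic nitrogen gives a 1.3-fold lower number from compound 3 to compound 4 (0.11 log units; within the scatter) in this assay and so shows that, for these two compounds, where the hydroxyl sits on the phenyl ring makes no difference beyond the scatter. The comparisons with the other phenyl groups, a 1.3-fold higher number from compound 1 to compound 4 (0.11 log units; within the scatter) and a 1.3-fold lower number from compound 2 to compound 4 (0.11 log units; within the scatter) again, also stay within the scatter, so the nitrile, fluoro and hydroxyl compounds cannot be told apart here. Nothing available explains this flat result. Going by these compounds, whether an amine or a carboxylic acid on the phenyl ring, or a longer alkyl chain in place of that ring, would shift the number beyond the scatter remains open.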